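Piperidin-4-yl in Place of Pyrrolidin-3-yl

This account rests on a few compounds, and the source may have more. Where it says the series, first, only, none or still open, it means among the compounds named here.

In a functional assay on HT-29 cells (Homo sapiens) for inhibition, read by luminescence and CellTiter-Glo, with a stated time of 24 h (on this read-out lower numbers stand for an effect already at smaller amounts and higher numbers for an effect only at larger amounts of compound), compound 2 (`CN1C(=S)[C@@H](NC(=O)c2nc(Cc3ccccc3)n(C3CCNC3)n2)COc2ccccc21`) gives 1070 nM, within the scatter of compound 1 (`CCCCCn1nc(C(=O)N[C@H]2COc3ccccc3N(C)C2=S)nc1Cc1ccccc1`) at 805 nM. Compound 3 (`CN1C(=S)[C@@H](NC(=O)c2nc(Cc3ccccc3)n(C3CCNCC3)n2)COc2ccccc21`) differs from compound 2 as follows: piperidin-4-yl in place of pyrrolidin-3-yl on an aromatic nitrogen. Among the compounds with values here, only one measured step bears on this change, a 1.3-fold higher number from compound 1 to compound 2 (0.12 log units; within the scatter), with pyrrolidin-3-yl in place of pentyl on an aromatic nitrogen. That exchange stayed within the scatter, so no shift beyond the scatter is expected in this assay. The estimated step is a 1.1-fold lower number from compound 2 to compound 3 (0.03 log units; within the scatter). Compound 3 is expected at 1000 nM, with an estimated range of 450 nM to 2300 nM.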

Compound 3, half-maximal effective concentration: 1000 nM
For compound 3 middle estimate and measured number coincide at the digits printed; the range from low to high includes it.
By their numbers in this assay, from the lowest: compounds 1, 3 and 2 (each within the scatter of the next).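

In this assay the piece now holds a six-membered ring at this position, with a 1.1-fold lower number from compound 2 to compound 3 (0.03 log units; within the scatter) and with a 1.2-fold higher number from compound 1 to compound 3 (0.09 log units; within the scatter). On this aromatic nitrogen, the five-membered ring of pyrrolidin-3-yl, the six-membered ring of piperidin-4-yl and the open pentyl chain thus all lie within the scatter of one another. No evidence is available to account for this. The compounds shown leave open whether a carboxylic acid or a tertiary amine at this position would also stay within the scatter.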